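Changing the Phenyl Substituent on a Shared Core

The compounds below may be only part of what the source reports. "The series", "measured", "known", "first", "only" and "open" are said of these compounds alone.

Measured compounds:
compound 1 `C=C(Br)C(=O)Nc1ccc(/C=C2\SC(=O)N(Cc3ccc(Cl)cc3)C2=O)cc1`: 3400 nM
compound 2 `C=C(Br)C(=O)Nc1ccc(/C=C2\SC(=O)N(Cc3ccc(C(F)(F)F)cc3)C2=O)cc1`: 12000 nM

In a functional assay on L1210 cells (Mus musculus) for cytotoxicity, read by cell counting, with a stated time of 2 days (a lower number here means a stronger inhibitor, a higher number a weaker inhibitor), compound 1 gives 3400 nM and compound 2 gives 12000 nM. For the measured compounds named here, compound 2 stands highest of the two numbers; the only measured step is a 3.5-fold higher number from compound 1 to compound 2 (0.55 log units; beyond the scatter). From the compounds shown here alone, compound 3 `C=C(Br)C(=O)Nc1ccc(/C=C2\SC(=O)N(Cc3cccc(F)c3)C2=O)cc1` is untested and differs from compound 2 by 3-fluorophenyl in place of 4-(trifluoromethyl)phenyl on a saturated chain carbon bound to an amide-type nitrogen in a ring. That one step bears on this change only loosely, since it exchanges a different group at the same place, but it shows that such a swap shifts the number modestly. A modest step toward lower numbers is therefore expected. Compound 3 is estimated at 5000 nM (range 1800 nM to 14000 nM), an expected step of a 2.4-fold lower number from compound 2 to compound 3 (0.38 log units; beyond the scatter).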

Compound 3, half-maximal inhibitory concentration: 1200 nM
Beside the measured number, compound 3's estimate is 4.2-fold (0.62 log units) above it, and the stated range ends above it.
By their numbers in this assay, from the lowest: compound 3; then compound 1; then compound 2.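

In this assay placing 3-fluorophenyl at this position brings a 10-fold lower number from compound 2 to compound 3 (1.00 log units; beyond the scatter) and also a 2.8-fold lower number from compound 1 to compound 3 (0.45 log units; beyond the scatter) and so makes compound 3 the strongest inhibitor of the three. Compound 1 and compound 2 showed only a rise in the number, whereas this change shows that a different phenyl group can take it below both. No available evidence explains this drop.

From the compounds shown here alone, each step changes both the substituent and its place on the ring, so their separate contributions remain unknown. Going by these compounds, how an amine or a carboxylic acid on the phenyl ring would perform also remains open.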